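Aryl amide variation on the shared tetrahydroquinoline-type series

This account rests on a few compounds, and the source may have more. Where it says the series, first, only, none or still open, it means among the compounds named here.

Measured compounds:
compound 1 `COc1cc2c(cc1N1C[C@@H](C)N(C)[C@@H](C)C1)N(C(=O)c1ccc(-c3ccc(-c4noc(C)n4)cc3C)cc1)CC2`, 15.9 nM
compound 2 `COc1cc2c(cc1N1C[C@@H](C)N(C)[C@@H](C)C1)N(C(=O)Nc1cccc(Cl)c1F)CC2`, 200 nM
compound 3 `COc1cc2c(cc1N1C[C@@H](C)N[C@@H](C)C1)N(C(=O)c1ccc(-c3cc(C)ncc3C)cc1)CC2`, 501 nM

In an assay on isolated protein for binding affinity to 5-hydroxytryptamine receptor 1D (Homo sapiens) (on this read-out lower numbers stand for stronger inhibition and higher numbers for weaker inhibition), compound 3 gives the highest number of the three. Compound 2 comes nearest, at a smaller number that lies beyond the scatter, and compound 1, with the largest gap, sits furthest away at the smallest number. For the measured compounds named here, no single-point steps between the measured compounds are available, so none is stated here.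

Compound 4 `COc1cc2c(cc1N1C[C@@H](C)N[C@@H](C)C1)N(C(=O)c1ccc(-c3ccc(C(C)=O)cc3C)cc1)CC2` is the next member to be measured in this assay. It differs from compound 3 in one place: 4-acetyl-2-methylphenyl in place of 2,5-dimethylpyridin-4-yl on an aromatic carbon. The entering group sits para to a large group on the aromatic carbon that previously carried the pyridinyl.

Going by the values given here, the expectation is that this exchange moves compound 4 toward a lower number than compound 3, by a step of a 2.0-fold lower number from compound 3 to compound 4 (0.30 log units; within the scatter), though the range is kept wide since no directly comparable step has been measured. In this assay compound 4 is therefore estimated at 250 nM, between 80 nM and 800 nM.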

Compound 4, inhibition constant: 398 nM
Compound 4: middle estimate off by 1.6-fold (0.20 log units), on the low side; measured number inside the range.
By their numbers in this assay, from the lowest: compound 1; then compounds 2, 4 and 3 (each within the scatter of the next, the first and the last beyond it).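

Within this assay the exchange gives a 1.3-fold lower number from compound 3 to compound 4 (0.10 log units; within the scatter) and so does not separate the two compounds. At this aromatic carbon, a six-membered aromatic ring of carbon only bearing an acetyl group reads the same as a ring with one hetero atom, and the step gives this series its first direct reading of a change at this place. The change adds heavy atoms and a double bond outside the rings, yet the pair stays within the scatter, and no supporting data bear on why the two compounds read alike.

As far as these compounds go, whether this place stays as flat with a charged or donor-bearing group remains open, for example a carboxylic acid or an aminomethyl group in place of the acetyl. Also open, from the compounds shown here alone, is how an unsubstituted phenyl would read against 4-acetyl-2-methylphenyl, which would test the ring methyl.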